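A few compounds are considered here, and "the series" means these few. Any claim that something is new, unique, unknown or untested is made for them only; others in the source may bear on it.

The starting point is compound 1 `Cc1ccc(C2CN(S(=O)(=O)c3ccccc3)C(=O)N2)cc1`, tested in a functional assay on SK-MEL-2 cells (Homo sapiens) for cytotoxicity; a higher number here means a weaker inhibitor, a lower number a stronger inhibitor. In this assay compound 1 gives only a limit, > 316000 nM, so its true number is not known (the limit of > 316000 nM in this assay, at which 1 of the 3 values shown sits). Two related compounds have real numbers: compound 2 `Cc1ccc(C2CN(S(=O)(=O)c3ccc(Cl)cc3)C(=O)N2)cc1` gives 123000 nM, and compound 3 `O=C1NCC(c2ccc(Br)cc2)N1S(=O)(=O)c1ccc2c(c1)CCC2` gives 119000 nM. Going by the values given here, the only step between measured compounds that differ in one place is an at least 2.5-fold lower number from compound 1 to compound 2 (0.40 log units; beyond the scatter), where a chloro group is added on the sulfonyl-bearing ring.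

Compound 4 `O=C1NC(c2ccccc2)CN1S(=O)(=O)c1ccccc1` differs from compound 1 at another place: hydrogen in place of methyl on an aromatic carbon, para to a large group, so that the 4-methylphenyl becomes a phenyl. Among the compounds with values here, no measured step touches this position, so the step from compound 1 to compound 2 gives no direct guide, and compound 1 itself sits at the limit. The expectation is therefore no step beyond the scatter, a step that the limit leaves unreadable from compound 1 to compound 4, with the number most likely again only a limit. Compound 4 is expected to give about 400000 nM, within the range from 150000 nM to 1000000 nM.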

Compound 4, half-maximal inhibitory concentration: 116000 nM
Compound 4: the middle estimate sits 3.4-fold (0.54 log units) above what was measured; the measured number lies below the stated range.
By their numbers in this assay, from the lowest: compounds 4, 3 and 2 (each within the scatter of the next). At a limit, above all of these: compound 1.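

In this assay, hydrogen in place of methyl on an aromatic carbon, para to a large group, gives an at least 2.7-fold lower number from compound 1 to compound 4 (0.43 log units; beyond the scatter). The earlier step concerned only the sulfonyl-bearing ring, so this result adds a second place where a small change moves the number beyond the scatter: with the 4-methylphenyl changed to phenyl, compound 4 gives a real value of 116000 nM and the methyl is not needed for a measurable number. Compound 1 has only a limit, so the step gives a minimum size and not its true size: the limit of > 316000 nM in this assay, at which 1 of the 4 values shown sits.

The compounds shown leave open how an amine or a carboxylic acid in this same position would read in this assay. They also leave open whether a chloro group on the sulfonyl-bearing ring would lower the number further when the 4-methylphenyl is replaced by phenyl.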